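The source may hold more compounds than are shown below. What is called first, only, known or untested is meant among the compounds shown, and "the series" means these compounds.

For the measured compounds named here, in an assay for inhibition of cathepsin S (Homo sapiens) (a lower number here means a stronger inhibitor, a higher number a weaker inhibitor), compound 1 `CC(C)C[C@H](NC(=O)N1CCOCC1)C(=O)N[C@H](C#N)CCc1ccccc1` gives 47 nM, the lowest of the three numbers measured so far. Compound 2 `CC(C)C[C@H](NC(=O)N1CCOCC1)C(=O)NCC#N` gives 124 nM, and compound 3 `CC(C)C[C@H](NC(=O)N1CCOCC1)C(=O)N[C@H](C#N)C(C)(C)C` gives 107000 nM. The measured steps of a 2.6-fold higher number from compound 1 to compound 2 (0.42 log units; beyond the scatter), a 2300-fold higher number from compound 1 to compound 3 (3.36 log units; beyond the scatter) and an 860-fold higher number from compound 2 to compound 3 (2.94 log units; beyond the scatter) all change the group on the saturated chain carbon bound to the amide-type nitrogen and the triple-bonded carbon. Compound 4 `CC(C)(C)C[C@H](NC(=O)N1CCOCC1)C(=O)N[C@H](C#N)CCc1ccccc1` differs from compound 1 at another place: methyl in place of hydrogen on a saturated chain carbon bound to three saturated chain carbons, which cut one bond further out reads isobutyl to neopentyl. Going by the values given here, no measured step touches this place, so none bears on the change directly. In this assay compound 4 is therefore expected to show no more than a modest step, a 1.3-fold higher number from compound 1 to compound 4 (0.11 log units; within the scatter). Compound 4 is estimated at 60 nM, with a range from 20 nM to 250 nM.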

Compound 4, half-maximal inhibitory concentration: 23 nM
Estimate against measurement, compound 4: 2.6-fold (0.42 log units) above; low and high end bracket the measured number.
By their numbers in this assay, from the lowest: compound 4; then compound 1; then compound 2; then compound 3.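

Going from isobutyl to neopentyl in this assay gives a 2.0-fold lower number from compound 1 to compound 4 (0.31 log units; beyond the scatter), so the added methyl on the saturated chain carbon bound to three saturated chain carbons does not cost inhibition here. For the compounds shown here, the earlier steps all changed another place, so this is the first reading of this one. Nothing available accounts for the lower number. This single pair leaves open how a longer chain or a cyclohexylmethyl group would read at this place. It also leaves open whether neopentyl gives a similar step with hydrogen or tert-butyl in place of phenethyl.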